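From pyridin-2-yl to pyridazin-3-yl on a shared core

This account rests on a few compounds, and the source may have more. Where it says the series, first, only, none or still open, it means among the compounds named here.

In a physicochemical assay for solubility, in phosphate buffer, with a stated time of 2 h, at pH 7.4 (on this read-out higher numbers stand for higher solubility and lower numbers for lower solubility), compound 1 `Cc1ccc(Nc2nc(-c3ccccn3)cs2)nc1` gives 10000 nM. In this assay compound 2 `Clc1ccc(Nc2nc(-c3ccccn3)cs2)nc1` returns only a limit, < 10000 nM, and not a number. Compound 3 `Clc1ccc(Nc2nc(-c3cccnn3)cs2)nc1` carries pyridazin-3-yl in place of pyridin-2-yl on an aromatic carbon of the five-membered aromatic ring, next to the ring nitrogen (pyridazin-3-yl in place of pyridin-2-yl on an aromatic carbon). One measured step stands near this change: a number no higher from compound 1 to compound 2 (the limit leaves the size open), with chloro in place of methyl on an aromatic carbon. Its size cannot be read, and it concerns a different place, so it offers no size for the new exchange. For the measured compounds named here, with only that step to go on, no shift beyond the usual scatter is expected in this assay, in either direction. The expected step is a step that the limit leaves unreadable from compound 2 to compound 3. Compound 3 is estimated at 5000 nM, with an expected range from 1500 nM to 15000 nM.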

Compound 3, solubility: 20000 nM
Estimate against measurement, compound 3: 4.0-fold (0.60 log units) below, outside the stated range (above it).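

For the compounds shown here, with compound 1 and compound 2 both carrying pyridin-2-yl on the aromatic carbon next to the ring nitrogen, the earlier compounds said nothing about this place, and the exchange for pyridazin-3-yl now gives, in this assay, an at least 2.0-fold higher number from compound 2 to compound 3 (0.30 log units; that floor lies within the scatter). The printed floor is all that this step fixes, and it does not on its own carry the change beyond the usual scatter. Its full size cannot be read, as the value for compound 2 is a limit and not a number: the limit of < 10000 nM in this assay, at which 1 of the 3 values shown sits.

On these data alone, whether the same exchange gives a similar step with methyl in place of chloro, on the core of compound 1, stays open. Also open, as far as these compounds go, is how this assay responds at this place to a group such as an amine or a carboxylic acid on the six-membered ring.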